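A few compounds are considered here, and "the series" means these few. Any claim that something is new, unique, unknown or untested is made for them only; others in the source may bear on it.

Compound 1 `O=c1nc(-c2ccc(F)cc2)ss1`: 33.7%
Compound 2 `Cc1sc(-c2nsc(=O)o2)cc1[N+](=O)[O-]`: 53.8%

Both were tested in an ADME assay on L02 cells (Homo sapiens) for inhibition, read by MTT assay, with a stated time of 48 h, tested at 100 uM; a lower number here means less inhibition, a higher number more inhibition at the concentration tested (going by the name of the read-out). Compound 2 gives 53.8%, the higher of the two numbers, and compound 1 gives 33.7%; the gap between them lies beyond the usual scatter of this measurement. Compound 3 `Cc1ccc(-c2nsc(=O)o2)s1` has not yet been measured. It differs from compound 2 in a single place: hydrogen in place of nitro on an aromatic carbon. For the measured compounds named here, no pair of measured compounds that differ in only one place is available, so there is no measured step of this kind to lean on. Since the nitro-bearing compound 2 gives 53.8%, the expected step of a number 13.8 percentage points lower from compound 2 to compound 3 (beyond the scatter) points downward, of a size near the edge of the scatter. Compound 3 is therefore estimated at 40%, with a range from 22% to 58%.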

Compound 3, a percentage reported as inhibition, at one concentration (the size of the read-out at that concentration, not a potency): 25.1%
Estimate against measurement, compound 3: 14.9 percentage points above, and the stated range covers the measured number.
By their numbers in this assay, from the lowest: compounds 3 and 1 (each within the scatter of the next); then compound 2.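

For the compounds shown here, on this aromatic carbon, next to the ring atom that bears a methyl group, hydrogen in place of nitro gives a number 28.7 percentage points lower from compound 2 to compound 3 (beyond the scatter) in this assay and provides the first measured comparison of two compounds that differ in only one place. It shows that the group at this position can change the reading by more than ordinary repeat-to-repeat variation, with the nitro-bearing compound 2 giving the higher inhibition of the pair. No measurement shown explains why the number moves.

As far as these compounds go, whether another group at this position, such as an amine, a nitrile or a carboxylic acid, would give a number nearer that of compound 2 or compound 3 remains open. A single pair also leaves open whether swapping nitro for hydrogen would give a similar step on a different core.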